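The source may hold more compounds than are shown below. What is called first, only, known or untested is meant among the compounds shown, and "the series" means these compounds.

Among the measured compounds shown here, compound 2 `O=c1cc(CCBr)c2ccc(OCc3cccc(Cl)c3)cc2o1` gives 32.4 nM in an assay on brain (strain Sprague-Dawley) for inhibition of Amine oxidase [flavin-containing] B (Rattus norvegicus), read by spectrophotometry (a lower number here means a stronger inhibitor, a higher number a weaker inhibitor), the higher of the two numbers measured so far, while compound 1 `O=c1cc(CCO)c2ccc(OCc3cccc(Cl)c3)cc2o1` gives 7.41 nM. For the measured compounds named here, the only recorded step, a 4.4-fold higher number from compound 1 to compound 2 (0.64 log units; beyond the scatter), raised the number when bromo replaced hydroxy. Compound 3 `NC(=O)CCc1cc(=O)oc2cc(OCc3cccc(Cl)c3)ccc12` differs from compound 2 by carbamoyl in place of bromo on a saturated chain carbon, two bonds along the chain from an aromatic carbon. Because a 4.4-fold higher number from compound 1 to compound 2 (0.64 log units; beyond the scatter) went upward when a group carrying a hydrogen-bond donor and acceptor gave way to bromo, and the entering carbamoyl again brings one donor and one acceptor, a downward step beyond the scatter, a 3.2-fold lower number from compound 2 to compound 3 (0.51 log units; beyond the scatter), is expected for compound 3. The estimate for compound 3 is 10 nM, within 3 nM to 35 nM.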

Compound 3, half-maximal inhibitory concentration: 15.1 nM
Beside the measured number, compound 3's estimate is 1.5-fold (0.18 log units) below it, within the range that was stated.
By their numbers in this assay, from the lowest: compound 1; then compound 3; then compound 2.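

In this assay carbamoyl in place of bromo gives a 2.1-fold lower number from compound 2 to compound 3 (0.33 log units; beyond the scatter) and so moves the number back toward that of compound 1, which carries hydroxy. The recovery is only partial: carbamoyl in place of hydroxy gives a 2.0-fold higher number from compound 1 to compound 3 (0.31 log units; beyond the scatter) and so the two groups are not interchangeable at this position. Among these three compounds the order runs hydroxy, then carbamoyl, then bromo, from the lowest number to the highest.

On these data alone, how an amine, a carboxylic acid or a longer chain would compare at this position remains open. Nothing available here explains the differences among the three groups.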